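Fluoro to Methyl: What to Expect for Compound 4

The compounds below may be only part of what the source reports. "The series", "measured", "known", "first", "only" and "open" are said of these compounds alone.

Compound 1, `Cc1cccc(-c2cc3occ(C)c3c(=O)o2)c1`, gives 1.5 uM in a functional assay on SK-BR-3 cells (Homo sapiens) for cytotoxicity, read by sulforhodamine B assay, with a stated time of 72 h; on this read-out lower numbers stand for an effect already at smaller amounts and higher numbers for an effect only at larger amounts of compound. Compound 2, `Cc1coc2cc(-c3cccc(F)c3)oc(=O)c12`, gives 20.5 uM in this assay. Compound 3, `Cc1coc2cc(-c3ccc(F)cc3)oc(=O)c12`, gives 19.3 uM in this assay.

Compound 4, `Cc1ccc(-c2cc3occ(C)c3c(=O)o2)cc1`, has not yet been measured. Compound 2 and compound 3 are built from the same atoms joined differently; the difference between the two cores is not broken down here, and their two values lie within the usual scatter of each other. Among the measured compounds shown here, the one measured step with a single change is a 14-fold lower number from compound 2 to compound 1 (1.14 log units; beyond the scatter), described as methyl in place of fluoro on an aromatic carbon. Compound 4 differs from compound 3 by the same kind of change, methyl in place of fluoro on an aromatic carbon: in compound 2 and compound 1 the place is meta to a large group, in compound 3 and compound 4 it is para to a large group, so the earlier step is a guide rather than a copy. Compound 4 is expected to show a 6.4-fold lower number from compound 3 to compound 4 (0.81 log units; beyond the scatter), an expectation resting on compound 1 and compound 2 through a 14-fold lower number from compound 2 to compound 1 (1.14 log units; beyond the scatter), tempered by the different place. Compound 4 is estimated at 3 uM, between 1 uM and 12 uM.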

Compound 4, concentration for half-maximal effect: > 83.3 uM
Compound 4 gave a limit, no number; the forecaster's own chance of this, stated with the estimate: 2%; at least 27-fold (1.44 log units) between middle value and limit.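

In this assay compound 4 gives > 83.3 uM, which is a limit of the assay and not a number. Even so, the change can be read as an at least 4.3-fold higher number from compound 3 to compound 4 (0.63 log units; beyond the scatter), which runs opposite to a 14-fold lower number from compound 2 to compound 1 (1.14 log units; beyond the scatter). Methyl in place of fluoro on an aromatic carbon therefore cannot simply be carried from one core to another in this series, although two pairs do not show what lies behind the gap, and the true size of the second step stays unknown: the same change on two cores in this assay, a 14-fold lower number (1.14 log units; beyond the scatter) from compound 2 to compound 1 and an at least 4.3-fold higher number (0.63 log units; beyond the scatter) from compound 3 to compound 4, at least 58-fold (1.77 log units) apart, beyond the scatter of two such steps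

The compounds shown leave open whether the opposite steps follow the place of the change on the aromatic ring or some other difference between the two cores. They also leave open how a group other than fluoro or methyl, such as an amine, a carboxylic acid or a longer chain, would behave at the same place.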